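The source may hold more compounds than are shown below. What is called first, only, known or untested is meant among the compounds shown, and "the series" means these compounds.

Compounds measured in a functional assay on HEK293 cells for negative allosteric modulation of metabotropic glutamate receptor 5 (Homo sapiens), read by calcium flux, with a stated time of 20 min; on this read-out lower numbers stand for stronger inhibition and higher numbers for weaker inhibition:
Compound 1 `O=C(c1ccccc1)N1CCn2nc(-c3cccnc3)cc2C1`; in this assay compound 1 gives > 10000 nM, which is a limit of the assay.
Compound 2 `Cc1ccnc(-c2cc3n(n2)CCN(C(=O)c2ccccc2)C3)c1`; in this assay compound 2 gives 451 nM.

Among the measured compounds shown here, compound 2 carries the only number, the other value being a limit (the limit of > 10000 nM in this assay, at which 1 of the 2 values shown sits). Compound 3 `Cc1cccc(-c2cc3n(n2)CCN(C(=O)c2ccccc2)C3)n1` differs from compound 2 by 6-methylpyridin-2-yl in place of 4-methylpyridin-2-yl on an aromatic carbon. For the measured compounds named here, the one measured step, an at least 22-fold lower number from compound 1 to compound 2 (1.34 log units; beyond the scatter), swapped the whole ring and does not address where the methyl sits. A smaller shift is expected for a 2.0-fold higher number from compound 2 to compound 3 (0.30 log units; within the scatter), most likely toward weaker inhibition, with wide uncertainty. Compound 3 is therefore estimated at 900 nM, within 200 nM to 5000 nM.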

Compound 3, half-maximal inhibitory concentration: 568 nM
The estimate for compound 3 lay 1.6-fold (0.20 log units) above the measured number; measured number inside the range.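

In this assay, 6-methylpyridin-2-yl in place of 4-methylpyridin-2-yl gives a 1.3-fold higher number from compound 2 to compound 3 (0.10 log units; within the scatter), so these two methyl placements are not told apart on this aromatic carbon. Against pyridin-3-yl, the 6-methylpyridin-2-yl group also gives a large change, an at least 17-fold lower number from compound 1 to compound 3 (1.24 log units; beyond the scatter), as the 4-methylpyridin-2-yl group did. The value of compound 1 is a limit, so both comparisons with it give only a bound: the limit of > 10000 nM in this assay, at which 1 of the 3 values shown sits.

The compounds shown do not separate the share of the methyl from that of the pyridin-2-yl ring, which an unsubstituted pyridin-2-yl would address. Also open, as far as these compounds go, is what an ethyl or methoxy group in place of the methyl would give.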